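Exchanging one substituted phenyl group on compound 2

The compounds below may be only part of what the source reports. "The series", "measured", "known", "first", "only" and "open" are said of these compounds alone.

Compound 1 `COc1ccc(C(=O)c2cc(C)ccc2OCC(=O)NNC(=O)c2cc3ccccc3oc2=O)cc1` gives 43400 nM
Compound 2 `Cc1ccc(OCC(=O)NNC(=O)c2cc3ccccc3oc2=O)c(C(=O)c2cccc(Cl)c2)c1` gives 67400 nM

For the measured compounds named here, in a functional assay on DLA cells (Mus musculus) for cytotoxicity, read by LDH release, with a stated time of 48 h (on this read-out higher numbers stand for weaker inhibition and lower numbers for stronger inhibition), compound 2 cannot be separated from the only other measured compound, and the comparison is a 1.6-fold higher number from compound 1 to compound 2 (0.19 log units; within the scatter). Compound 3 `Cc1ccc(OCC(=O)NNC(=O)c2cc3ccccc3oc2=O)c(C(=O)c2ccccc2Br)c1` alters compound 2 in one place: 2-bromophenyl in place of 3-chlorophenyl on a carbonyl carbon. Going by the values given here, the one measured exchange on this carbonyl carbon is a 1.6-fold higher number from compound 1 to compound 2 (0.19 log units; within the scatter), so no step beyond the scatter, in either direction, is expected in this assay. The expected step is a 1.2-fold lower number from compound 2 to compound 3 (0.09 log units; within the scatter). Compound 3 is estimated at 55000 nM, with an expected range of 22000 nM to 130000 nM.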

Compound 3, half-maximal inhibitory concentration: 10600 nM
For compound 3 the middle estimate is 5.2-fold (0.72 log units) above the measured one; measured number below the stated range.
By their numbers in this assay, from the lowest: compound 3; then compounds 1 and 2 (each within the scatter of the next).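

In this assay, the group on this carbonyl carbon now matters beyond the scatter: 2-bromophenyl in place of 3-chlorophenyl gives a 6.4-fold lower number from compound 2 to compound 3 (0.80 log units; beyond the scatter) and, in place of 4-methoxyphenyl, a 4.1-fold lower number from compound 1 to compound 3 (0.61 log units; beyond the scatter) as well. For the compounds shown here, the earlier exchange had left compound 1 and compound 2 inseparable, so compound 3 is the first to stand apart, with the lowest number of the three. No evidence here accounts for this step. From the compounds shown here alone, the exchange alters both the halogen and its place on the ring, so which of these counts stays open. A 2-chlorophenyl or 3-bromophenyl group would separate the two.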